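A few compounds are considered here, and "the series" means these few. Any claim that something is new, unique, unknown or untested is made for them only; others in the source may bear on it.

Measured so far in a functional assay on HCT-116 cells (Homo sapiens) for inhibition, read by sulforhodamine B assay, with a stated time of 48 h; a lower number here means a stronger inhibitor of growth, a higher number a weaker inhibitor of growth:
- compound 1 `CCN(C(=O)c1cc(C(C)C)c(O)cc1O)c1ccc(NC(=O)CCCCCCC(=O)NO)cc1` gives 3560 nM
- compound 2 `CC(C)c1cc(C(=O)Nc2cccc(NC(=O)CCCCCCC(=O)NO)c2)c(O)cc1O` gives 6230 nM
- compound 3 `CC(C)c1cc(C(=O)N(C)c2ccc(NC(=O)CCCCCCCCC(=O)NO)cc2)c(O)cc1O` gives 590 nM

Compound 1 (3560 nM) lies within the scatter of compound 2 (6230 nM), while compound 3 (590 nM) shows a lower number, beyond the scatter. Compound 4 `CC(C)c1cc(C(=O)Nc2ccc(NC(=O)CCCCCCC(=O)NO)cc2)c(O)cc1O` departs from compound 1 in one place (hydrogen in place of ethyl on an amide-type nitrogen), with hydrogen in place of ethyl on an amide-type nitrogen. Within the data shown here, no measured pair isolates this change. Compound 2 (6230 nM) also carries hydrogen on an amide-type nitrogen, so a small step in this assay toward a higher number is expected, none beyond the scatter. The estimated step runs a 1.3-fold higher number from compound 1 to compound 4 (0.10 log units; within the scatter) in this reading. For compound 4 the expected value is 4500 nM, with an estimated range from 1700 nM to 11000 nM overall.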

Compound 4, concentration for 50% growth inhibition: 5430 nM
Estimate against measurement, compound 4: 1.2-fold (0.08 log units) below; measured number inside the range.
By their numbers in this assay, from the lowest: compound 3; then compounds 1, 4 and 2 (each within the scatter of the next).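

In this assay, among these compounds, the pair gives the first direct reading at this amide-type nitrogen: hydrogen in place of ethyl gives a 1.5-fold higher number from compound 1 to compound 4 (0.18 log units; within the scatter) and so stays within the scatter. On this nitrogen, with its aromatic carbon and carbonyl carbon neighbours, ethyl and hydrogen therefore cannot be told apart in growth inhibition. No measurement shown here offers an explanation for this result. Going by these compounds, whether a larger group on this nitrogen, such as benzyl or a chain ending in an amine, would also leave the number within the scatter remains open.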